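The source may report more compounds than this note shows. Statements on the series, on what has been measured and on what is new or still open speak of the compounds shown alone.

Measured compounds in a functional assay on A549 cells (Homo sapiens) for inhibition, read by sulforhodamine B assay, with a stated time of 48 h; on this read-out higher numbers stand for weaker inhibition of growth and lower numbers for stronger inhibition of growth:
compound 1 `COC(=O)[C@@]1(C)CCC=C2[C@@H]1CC[C@@H](C)[C@]2(C)Cc1c[nH]c2ccc(Cl)cc12` gives 16000 nM;
compound 2 `COC(=O)[C@@]1(C)CCC=C2[C@@H]1CC[C@@H](C)[C@]2(C)Cc1c(C)[nH]c2ccc(Cl)cc12` gives 17000 nM;
compound 3 `COC(=O)[C@@]1(C)CC[C@@H]2C3=C1CC[C@@H](C)[C@]3(C)Cc1c2[nH]c2ccccc12` gives 4600 nM.

Compound 1 and compound 2 differ only by methyl in place of hydrogen on an aromatic carbon and the step of a 1.1-fold higher number from compound 1 to compound 2 (0.03 log units; within the scatter) is small. Compound 3 rests on a different core; the difference between the two cores is not broken down here. Compound 4 `COC(=O)[C@@]1(C)CC[C@@H]2C3=C1CC[C@@H](C)[C@]3(C)Cc1c2[nH]c2ccc(C)cc12` is not yet measured and differs from compound 3 by methyl in place of hydrogen on an aromatic carbon. The change is the same kind as that from compound 1 to compound 2, but the place is not the same: in compound 2 the methyl sits on a five-membered aromatic ring with one nitrogen, next to the ring nitrogen; in compound 4 it sits on a six-membered aromatic ring of carbon only, meta to a fused ring and para to a fused ring. Given that the earlier step was within the scatter, the expected step of a 1.1-fold higher number from compound 3 to compound 4 (0.04 log units; within the scatter) in this assay is likewise small. The estimate for compound 4 is 5000 nM, between 2000 nM and 12000 nM.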

Compound 4, concentration for 50% growth inhibition: 16000 nM
The estimate for compound 4 lay 3.2-fold (0.51 log units) below the measured number; the measured number lies above the stated range.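

In this assay, methyl in place of hydrogen on an aromatic carbon gives a 3.5-fold higher number from compound 3 to compound 4 (0.54 log units; beyond the scatter), a loss of growth inhibition on the core of compound 3. The size of this step does not carry over between the two cores: the same change on two cores in this assay, a 1.1-fold higher number (0.03 log units; within the scatter) from compound 1 to compound 2 and a 3.5-fold higher number (0.54 log units; beyond the scatter) from compound 3 to compound 4, 3.3-fold (0.52 log units) apart, beyond the scatter of two such steps The result does not assign the gap to the core alone: the methyl sits on a five-membered aromatic ring with one nitrogen in compound 2 and on a six-membered aromatic ring of carbon only in compound 4, so core and place remain unseparated.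

Still open, from the compounds shown here alone, is how a methyl on the five-membered ring of the core of compound 3 would read. Also open, going by these compounds, is whether an amine or a carboxylic acid at the place of the methyl in compound 4 would shift the number in the same direction.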